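The compounds below may be only part of what the source reports. "The series", "measured", "known", "first", "only" and "open" are said of these compounds alone.

Compound 1 `C=C1[C@@H](O)[C@H](n2cnc3c(OC)nc(N)nc32)O[C@@H]1CO` and compound 2 `C=C1[C@@H](O)[C@H](n2cnc3c(S)nc(N)nc32)O[C@@H]1CO` share a core and differ in one place: sulfanyl in place of methoxy on an aromatic carbon. In a functional assay on MT4 cells (Homo sapiens) for inhibition (on this read-out lower numbers stand for stronger inhibition and higher numbers for weaker inhibition), compound 1 gives only a limit, > 500000 nM, which is a limit of this assay (the limit of > 500000 nM in this assay, at which 1 of the 3 values shown sits). In this assay compound 2 gives 12000 nM. The step is an at least 41-fold lower number from compound 1 to compound 2 (1.61 log units; beyond the scatter). Compound 3 `C=C1[C@H](n2cnc3c(OC)nc(N)nc32)O[C@H](CO)[C@H]1O` has the same atoms as compound 1, joined differently; the difference between the two cores is not broken down here. In this assay compound 3 gives 180000 nM. Compound 4 `C=C1[C@H](n2cnc3c(S)nc(N)nc32)O[C@H](CO)[C@H]1O`, not yet measured, differs from compound 3 by sulfanyl in place of methoxy on an aromatic carbon, the same change. The step from compound 3 to compound 4 is expected to be a 36-fold lower number from compound 3 to compound 4 (1.56 log units; beyond the scatter), resting on the step from compound 1 to compound 2, an at least 41-fold lower number from compound 1 to compound 2 (1.61 log units; beyond the scatter). Compound 4 is therefore estimated at 5000 nM, between 1000 nM and 30000 nM.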

Compound 4, half-maximal inhibitory concentration: 480 nM
For compound 4 the middle estimate is 10-fold (1.02 log units) above the measured one; measured number outside the range, below it.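

Sulfanyl in place of methoxy on an aromatic carbon gives a lower number in this assay on both cores, and the new step is a 380-fold lower number from compound 3 to compound 4 (2.57 log units; beyond the scatter). The direction of the change thus carries from the core of compound 1 to the core of compound 3, but whether its size carries as well cannot be said: the same change on two cores in this assay, an at least 41-fold lower number (1.61 log units; beyond the scatter) from compound 1 to compound 2 and a 380-fold lower number (2.57 log units; beyond the scatter) from compound 3 to compound 4; the limit leaves it open whether they differ. Among the compounds shown here, the earlier step rests on a limit rather than a number, the one held by compound 1: the limit of > 500000 nM in this assay, at which 1 of the 4 values shown sits.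

The compounds shown leave open whether other groups in this place, such as an amine or a longer chain like ethylsulfanyl, would follow on either core. They also leave open whether the change would hold on any core beyond these two.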